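The compounds below may be only part of what the source reports. "The series", "measured", "known", "first", "only" and "open" are said of these compounds alone.

Going by the values given here, in a functional assay on DU-145 cells (Homo sapiens) for inhibition, read by trypan blue exclusion, with a stated time of 96 h (on this read-out lower numbers stand for stronger inhibition of growth and higher numbers for weaker inhibition of growth), compound 2 `COc1ccc(/C=C(/SCc2ccc(Cl)cc2)C(=O)c2ccc(Cl)cc2)cc1` gives 10000 nM, the highest of the two numbers measured so far. Its nearest neighbour, compound 1 `O=C(/C(=C\c1ccc(Br)cc1)SCc1ccc(Cl)cc1)c1ccc(Cl)cc1`, gives 1000 nM in this assay. Among the compounds with values here, the only measured step, a 10-fold higher number from compound 1 to compound 2 (1.00 log units; beyond the scatter), shows that swapping the group on that aromatic ring shifts the number by a modest amount. Compound 3 `O=C(/C(=C\c1ccc(O)cc1O)SCc1ccc(Cl)cc1)c1ccc(Cl)cc1` differs from compound 2 by 2,4-dihydroxyphenyl in place of 4-methoxyphenyl on a double-bonded chain carbon bound to a double-bonded chain carbon. Within the data shown here, no measured step involves a hydroxyl, so the guidance is loose. The step is expected to be a 2.0-fold lower number from compound 2 to compound 3 (0.30 log units; within the scatter). Compound 3 is estimated at 5000 nM, with a range from 1000 nM to 25000 nM.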

Compound 3, concentration for 50% growth inhibition: 50000 nM
Compound 3: middle estimate off by 10-fold (1.00 log units), on the low side, and the stated range ends below it.
By their numbers in this assay, from the lowest: compound 1; then compound 2; then compound 3.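

Placing 2,4-dihydroxyphenyl on this double-bonded chain carbon gives a 5.0-fold higher number from compound 2 to compound 3 (0.70 log units; beyond the scatter) and a 50-fold higher number from compound 1 to compound 3 (1.70 log units; beyond the scatter), and here a higher number means weaker inhibition of growth. Among the three aryl groups compared at this position, the order from lowest to highest number is 4-bromophenyl, 4-methoxyphenyl, 2,4-dihydroxyphenyl, with every gap beyond the scatter. No measurement shown here accounts for these shifts. The compounds shown leave open whether a single hydroxyl would give the same shift as the two in compound 3. They also leave open how an amine or a carboxylic acid on this ring would compare.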